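From dimethylamino to amino on the shared core

The compounds below may be only part of what the source reports. "The series", "measured", "known", "first", "only" and "open" are said of these compounds alone.

Compound 1 `CCCCC(CCO)n1cnc2c(N)ncnc21` gives > 50000 nM as a limit
Compound 2 `CCCCCC(CCO)n1cnc2c(NC)ncnc21` gives > 50000 nM as a limit
Compound 3 `CCCCCC(CCO)n1cnc2c(N(C)C)ncnc21` gives > 50000 nM as a limit

All three results come from a functional assay on SW480 cells (Homo sapiens) for antiproliferative activity, read by MTT assay, with a stated time of 48 h (on this read-out lower numbers stand for stronger inhibition and higher numbers for weaker inhibition), and none of them is a number. Compound 3 stands at the limit of > 50000 nM in this assay, at which 3 of the 3 values shown sit, and so has only a limit to its name. Compound 4 `CCCCCC(CCO)n1cnc2c(N)ncnc21` differs from compound 3 by one change, amino in place of dimethylamino on an aromatic carbon. Among the compounds with values here, only one measured step bears on this change: a step that the two limits leave unreadable from compound 2 to compound 3 and no size can be taken from it. Compound 1, which carries amino, gives > 50000 nM as a limit too. No clear move is therefore expected in this assay and a further limit is the likeliest result. The estimated step is a step that the limit leaves unreadable from compound 3 to compound 4 in expectation only. For compound 4 the expected value is 60000 nM within an estimated range from 25000 nM to 150000 nM as a rough guide.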

Compound 4, half-maximal inhibitory concentration: > 50000 nM
Compound 4 ended at the assay's limit; the forecaster's own chance of this, stated with the estimate: 80%; the middle value lies beyond the limit too.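

No step can be read between compound 4 and compound 1, compound 2 or compound 3, as all four rest on one limit: the limit of > 50000 nM in this assay, at which 4 of the 4 values shown sit.

The compounds shown leave open whether changing the nitrogen substituents or the chain shifts activity at all.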